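The source may hold more compounds than are shown below. What is called first, only, known or untested is meant among the compounds shown, and "the series" means these compounds.

- Compound 1 `[O-][n+]1nc(N[C@@H]2C[C@H]3CC[C@@H]2C3)[n+]([O-])c2ccccc21`: 3.4 ug/mL
- Compound 2 `[O-][n+]1nc(NC2CCCCC2)[n+]([O-])c2ccc(F)cc21`: < 2.5 ug/mL

Both values come from an ADME assay on Vero cells (Chlorocebus sabaeus) for cytotoxicity, read by CellTiter-Glo, with a stated time of 72 h; on this read-out lower numbers stand for higher toxicity in this test and higher numbers for lower toxicity in this test. Compound 2 stands at the limit of < 2.5 ug/mL in this assay, at which 1 of the 2 values shown sits, so its value is a limit and not a number.

Compound 3 `[O-][n+]1nc(N[C@@H]2C[C@H]3CC[C@@H]2C3)[n+]([O-])c2ccc(F)cc21` keeps the core of compound 2 but changes the group on a nitrogen on an aromatic ring: a group of 7 heavy atoms (7 carbon; 2 five-membered non-aromatic rings of carbon only) in place of a group of 6 heavy atoms (6 carbon; one six-membered non-aromatic ring of carbon only), on a nitrogen on an aromatic ring.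

Going by the values given here, compound 1 gives 3.4 ug/mL, the only true number so far, so only a small change is expected in this assay. The expected step of a number no lower from compound 2 to compound 3 (the limit leaves the size open) stays within the scatter, with no clear direction. For compound 3 the estimate is 2.5 ug/mL, with an expected range from 1.1 ug/mL to 5 ug/mL.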

Compound 3, half-maximal cytotoxic concentration: < 2.5 ug/mL
Compound 3: only a limit was reported; the forecaster's own chance of this, stated with the estimate: 40%; the middle value sits exactly at the limit.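

Fluoro in place of hydrogen on an aromatic carbon can now be read for the first time: in this assay it gives an at least 1.3-fold lower number from compound 1 to compound 3 (0.13 log units; that floor lies within the scatter). Compound 3 has a limit and not a number, and the step between compound 2 and compound 3 cannot be read because both carry only limits: the limit of < 2.5 ug/mL in this assay, at which 2 of the 3 values shown sit.

Going by these compounds, the true size of the fluoro step remains open, so it may or may not exceed the usual scatter. Also open, on these data alone, is how a longer straight carbon chain or an amine-bearing group on that nitrogen would read in this assay.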